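Methyl for hydrogen on a second core in cytotoxicity

The source may hold more compounds than are shown below. What is called first, only, known or untested is meant among the compounds shown, and "the series" means these compounds.

Compound 1 `Cc1ncn2c(=O)[nH]c(=S)[nH]c12` and compound 2 `Cc1nc(C)n2c(=O)[nH]c(=S)[nH]c12` share one core. In a functional assay on CCRF-CEM cells (Homo sapiens) for cytotoxicity (a lower number here means that less compound is tolerated, a higher number that more compound is tolerated), compound 1 gives 786000 nM and compound 2 gives 526000 nM; the change methyl in place of hydrogen on an aromatic carbon made a step of a 1.5-fold lower number from compound 1 to compound 2 (0.17 log units; within the scatter). Compound 3 `Cc1ncn2c1NC=NC2N` has a different core; how the two cores differ is not broken down here. In this assay compound 3 gives 746000 nM. Compound 4 `Cc1nc(C)n2c1NC=NC2N` is not yet measured. It carries the same kind of change on the core of compound 3, (methyl in place of hydrogen on an aromatic carbon), the place now also next to the ring atom that bears a fused ring and two ring bonds from the ring atom that bears a fused ring. For this assay the step from compound 3 to compound 4 is expected near a 1.2-fold lower number from compound 3 to compound 4 (0.09 log units; within the scatter), resting on the earlier step of a 1.5-fold lower number from compound 1 to compound 2 (0.17 log units; within the scatter) staying within the scatter. Compound 4 is therefore estimated at 600000 nM, between 300000 nM and 1200000 nM.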

Compound 4, half-maximal cytotoxic concentration: 115000 nM
Beside the measured number, compound 4's estimate is 5.2-fold (0.72 log units) above it; the whole stated range lies above it.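

On the core of compound 3, methyl in place of hydrogen on an aromatic carbon gives a 6.5-fold lower number from compound 3 to compound 4 (0.81 log units; beyond the scatter), so in this assay the change does not carry over between the two cores at one size: the same change on two cores in this assay, a 1.5-fold lower number (0.17 log units; within the scatter) from compound 1 to compound 2 and a 6.5-fold lower number (0.81 log units; beyond the scatter) from compound 3 to compound 4, 4.3-fold (0.64 log units) apart, beyond the scatter of two such steps

Only on the core of compound 3 does the step lie beyond the scatter, while on the core of compound 1 it cannot be told from no change. Two pairs do not show which difference between the cores accounts for the gap, and they give no rule for any further core.

Only methyl is shown at this place, so an ethyl group, a longer chain, an amine or a carboxylic acid there remains open on both cores. Also open, from the compounds shown here alone, is how the same change behaves on a third core.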